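Removing the Chloro Group from Compound 3

The source may report more compounds than this note shows. Statements on the series, on what has been measured and on what is new or still open speak of the compounds shown alone.

Measured compounds in a functional assay on the whole organism with Mus musculus as the target; a lower number here means that less compound is needed, a higher number that more compound is needed for the effect:
compound 1, `O=c1oc2cccnc2n1CCN1CCN(c2cccc(C(F)(F)F)c2)CC1`: 11.4 mg/kg
compound 2, `COc1ccccc1N1CCN(CCn2c(=O)oc3cccnc32)CC1`: > 50 mg/kg
compound 3, `O=c1oc2cccnc2n1CCN1CCN(c2ccc(Cl)cc2)CC1`: > 50 mg/kg

In this assay compound 1 gives a number, 11.4 mg/kg. Compound 2 gives only a limit, > 50 mg/kg. Compound 3 likewise gives only a limit, > 50 mg/kg. Compound 3 therefore sits at the limit of > 50 mg/kg in this assay, at which 2 of the 3 values shown sit. Among the measured compounds shown here, the one step between measured compounds, a step that the two limits leave unreadable from compound 2 to compound 3, cannot be sized, so no measured step bears on the change to compound 4, `O=c1oc2cccnc2n1CCN1CCN(c2ccccc2)CC1`. That change is hydrogen in place of chloro on an aromatic carbon. With only a limit for compound 3, the step to compound 4 is expected to be an at least 1.2-fold lower number from compound 3 to compound 4 (0.09 log units; that floor lies within the scatter). Compound 4 is accordingly estimated at 40 mg/kg, within a range of 10 mg/kg to 120 mg/kg, and it may well again give only a limit.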

Compound 4, dose for half-maximal effect: 19.4 mg/kg
Compound 4: middle estimate off by 2.1-fold (0.31 log units), on the high side, within the range that was stated.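

In this assay, taking chloro off the ring gives an at least 2.5-fold lower number from compound 3 to compound 4 (0.41 log units; beyond the scatter), and the change from the methoxy compound gives an at least 2.5-fold lower number from compound 2 to compound 4 (0.41 log units; beyond the scatter). The step to the trifluoromethyl compound is a 1.7-fold higher number from compound 1 to compound 4 (0.23 log units; within the scatter), so hydrogen and trifluoromethyl cannot be told apart here. Compound 4 also stands outside the compounds that give only a limit and not a number: the limit of > 50 mg/kg in this assay, at which 2 of the 4 values shown sit.

On these data alone, the full size of the chloro and methoxy steps stays open. Also open, as far as these compounds go, is how fluoro or an amine would compare with hydrogen in the place that chloro held.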